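Stereochemical inversion at the piperidine ring in a sulfonylated pyrrolidine series

The compounds below may be only part of what the source reports. "The series", "measured", "known", "first", "only" and "open" are said of these compounds alone.

Compound 1 `Cc1ccc2[nH]c(C(=O)N[C@H]3CN(S(=O)(=O)c4ccccc4)C[C@@H]3C(=O)NC[C@@H]3CCCN3C)cc2c1` is the reference point of this series. In an ADME assay on cells (Hepatocyte, Rattus norvegicus) for metabolic stability (a lower number here means slower removal, a higher number faster removal of the compound), compound 1 gives 23 uL/min. Compound 2 `Cc1ccc2[nH]c(C(=O)N[C@H]3CN(S(=O)(=O)c4ccccc4)C[C@@H]3C(=O)N[C@@H]3CCCN(C)C3)cc2c1` replaces the amide-side group with 1-methylpiperidin-3-yl, and in this assay compound 2 gives 23 uL/min; the step of no change at the digits printed from compound 1 to compound 2 (within the scatter) lies within the scatter, so compound 2 stands level with compound 1 on the numbers shown. Compound 3 `Cc1ccc2[nH]c(C(=O)N[C@H]3CN(S(=O)(=O)c4ccccc4)C[C@@H]3C(=O)N[C@H]3CCCN(C)C3)cc2c1` is the next member. Its relation to compound 2 is the two compounds have the same atoms and bonds and differ only in configuration as drawn: 1 of 3 stereo elements differ; a stereocentre at a saturated ring carbon is drawn R in compound 2 and S in compound 3. Within the data shown here, the only measured step, from compound 1 to compound 2, concerned the identity of the amide-side group rather than its configuration, and it produced no change beyond the scatter, so there is no measured precedent for a configurational change on its own. With nothing in the data to indicate a shift in either direction, the step from compound 2 to compound 3 is expected to be no change at the digits printed from compound 2 to compound 3 (within the scatter). On that basis compound 3 is estimated at 23 uL/min, with a range from 12 uL/min to 46 uL/min.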

Compound 3, intrinsic clearance in a liver preparation (reported as CLH), per the amount of preparation that the assay uses: 23 uL/min
Compound 3: the middle estimate sits on the measured number at the digits printed; the range from low to high includes it.
By their numbers in this assay, from the lowest: compounds 1, 2 and 3 (each within the scatter of the next).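

In this assay, inverting the stereocentre at the saturated ring carbon of the 1-methylpiperidin-3-yl group gives no change at the digits printed from compound 2 to compound 3 (within the scatter), the first measured case in which configuration alone is the difference at this position. Set against the (1-methylpyrrolidin-2-yl)methyl group on the same amide-type nitrogen, the other drawn configuration gives no change at the digits printed from compound 1 to compound 3 (within the scatter), so both drawn forms of the 1-methylpiperidin-3-yl group now stand level with that group on the numbers shown. The pair therefore isolates a single variable, and at this position that variable leaves the read-out level: the fact that compounds 2 and 3 differ only in the configuration as drawn

The compounds shown leave open whether this level would hold with a different group on the amide-type nitrogen, such as a piperidin-3-yl without the methyl group, an amine on a longer chain or a carboxylic acid. They also leave open whether the other two stereo elements, which are drawn the same in compound 2 and compound 3, would behave in the same way in this assay if inverted.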